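Cyclopropyl to ethyl on the piperazine of compound 2

The source may report more compounds than this note shows. Statements on the series, on what has been measured and on what is new or still open speak of the compounds shown alone.

Values so far in an ADME assay for permeability, using PAMPA, at pH 7.4; a higher number here means that the compound crosses the layer faster, a lower number that the compound crosses the layer more slowly
- compound 1 `CN(C[C@@H]1Cc2c(cccc2N2CCNCC2)CN1)[C@H]1CCCc2cccnc21` gives 4 nm/s
- compound 2 `CN(C[C@H]1Cc2c(cccc2N2CCN(C3CC3)CC2)CN1)[C@H]1CCCc2cccnc21` gives 265 nm/s
- compound 3 `CC(C)N(C[C@H]1Cc2c(cccc2N2CCNCC2)CN1)[C@H]1CCCc2cccnc21` gives 16 nm/s

Compound 2 has the highest number of the three, and its gaps to compound 1 and to compound 3 both lie beyond the scatter. Within the data shown here, compound 2 is also the only measured compound with a group on the amine nitrogen in question, as 4-cyclopropylpiperazin-1-yl. Among the measured compounds shown here, no two measured compounds differ in one place only, so the series offers no direct measure of any single change.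

The next compound is compound 4 `CCN1CCN(c2cccc3c2C[C@H](CN(C)[C@H]2CCCc4cccnc42)NC3)CC1` with ethyl in place of cyclopropyl on an amine nitrogen in a ring and the rest of the structure stays as in compound 2. Compound 4 keeps a group on that nitrogen, so the reference point is compound 2 at 265 nm/s and not the lower numbers of compound 1 and compound 3.

A small downward move is expected, a 1.6-fold lower number from compound 2 to compound 4 (0.19 log units; within the scatter) in this assay and no larger than the scatter. Compound 4 is estimated at 170 nm/s with an expected range from 60 nm/s to 400 nm/s for the measurement.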

Compound 4, apparent permeability: 205 nm/s
The estimate for compound 4 lay 1.2-fold (0.08 log units) below the measured number; measured number inside the range.
By their numbers in this assay, from the lowest: compound 1; then compound 3; then compounds 4 and 2 (each within the scatter of the next).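

Among these compounds, this is the first matched pair: in this assay, the step at this amine nitrogen in a ring reads a 1.3-fold lower number from compound 2 to compound 4 (0.11 log units; within the scatter), so ethyl and cyclopropyl cannot be told apart here. The change removes the three-membered non-aromatic ring and takes the group from 3 heavy atoms to 2, yet the two numbers remain within the scatter of each other, a reading that holds only for this position on this shared core. Nothing measured here bears on why the two groups read alike.

Among the compounds shown here, compound 1 and compound 3 each differ from compound 2 and compound 4 in more than one place, so the series still gives no direct step from the free amine of the piperazine to either alkyl group, and what a group on this nitrogen contributes in itself stays open. As far as these compounds go, how a longer chain such as butyl, a branched group such as tert-butyl, or an acyl group such as acetyl would read on this nitrogen also remains open.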